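This account rests on a few compounds, and the source may have more. Where it says the series, first, only, none or still open, it means among the compounds named here.

Compound 2 `COc1cc(C(F)(F)F)cc(SC)c1C(=O)NC1(c2cccc(Cl)c2)CCCN(C)C1` gives the lower of the two numbers recorded in an assay on cells for inhibition of sodium- and chloride-dependent glycine transporter 1 (Homo sapiens) (a lower number here means that less compound is needed, a higher number that more compound is needed for the effect), at 25 nM; compound 1 `CN1CCCC(NC(=O)c2ccc(C(F)(F)F)cc2Br)(c2ccccc2)C1` gives 300 nM in this assay, a value well beyond the usual scatter above it. Compound 3 `COc1cc(C(F)(F)F)cc(SC)c1C(=O)NC1(c2cnccn2)CCCN(C)C1` differs from compound 2 by pyrazin-2-yl in place of 3-chlorophenyl on a saturated ring carbon. Going by the values given here, no measured pair shows this change, so its effect is uncertain; compound 3 is expected to need somewhat more than compound 2, a step of a 4.0-fold higher number from compound 2 to compound 3 (0.60 log units; beyond the scatter) in this assay, beyond the scatter but modest. Compound 3 is therefore estimated at 100 nM, within a range of 30 nM to 400 nM.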

Compound 3, half-maximal effective concentration: 1670 nM
Compound 3: the middle estimate sits 17-fold (1.22 log units) below what was measured; measured number above the stated range.
By their numbers in this assay, from the lowest: compound 2; then compound 1; then compound 3.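

Going by these compounds alone, compound 3 gives the first reading of a single change at this position: on the saturated ring carbon, pyrazin-2-yl in place of 3-chlorophenyl produces a 67-fold higher number from compound 2 to compound 3 (1.82 log units; beyond the scatter) in this assay, a large step. The outcome at this position therefore depends strongly on which aromatic ring is attached. Nothing available accounts for the size of this step.

On these data alone, it remains open whether the loss follows from the ring nitrogens of pyrazin-2-yl or from losing the chlorine. Pyridin-2-yl or an unsubstituted phenyl on the same core would separate these two possibilities.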